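The source may report more compounds than this note shows. Statements on the series, on what has been measured and on what is new or still open speak of the compounds shown alone.

Compound 2 `N#CC1=C(N)Oc2c(N)cc3nc4ccccc4nc3c2C12C(=O)N(Cc1cnnn1-c1ccc([N+](=O)[O-])cc1)c1ccccc12` is tested in a functional assay on HCT-116 cells (Homo sapiens) for antiproliferative activity, read by MTT assay, with a stated time of 48 h; a lower number here means a stronger inhibitor, a higher number a weaker inhibitor. In this assay compound 2 gives only a limit, > 50000 nM. Compound 1 `N#CC1=C(N)Oc2c(N)cc3nc4ccccc4nc3c2C12C(=O)N(Cc1cnnn1-c1ccccc1Cl)c1ccccc12` likewise gives only a limit in this assay, > 50000 nM. Within the data shown here, the single measured step is therefore not readable: a step that the two limits leave unreadable from compound 1 to compound 2. Compound 3 `N#CC1=C(N)Oc2c(N)cc3nc4ccccc4nc3c2C12C(=O)N(Cc1cnnn1-c1ccc(Cl)cc1[N+](=O)[O-])c1ccccc12` differs from compound 2 by 4-chloro-2-nitrophenyl in place of 4-nitrophenyl on an aromatic nitrogen. Among the measured compounds shown here, no measured step bears on this change, and both values shown sit at the limit (the limit of > 50000 nM in this assay, at which 2 of the 2 values shown sit), so no step beyond the scatter is expected. The expected step is a number no higher from compound 2 to compound 3 (the limit leaves the size open). Compound 3 is expected to give about 50000 nM, between 20000 nM and 100000 nM, most likely again as a limit.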

Compound 3, half-maximal inhibitory concentration: 28700 nM
Estimate against measurement, compound 3: 1.7-fold (0.24 log units) above, and the stated range covers the measured number.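

Among the three compounds, only compound 3 gives a real number rather than a limit in this assay, so a change in the aryl group on this aromatic nitrogen can bring a readable value. 4-Chloro-2-nitrophenyl gives an at least 1.7-fold lower number from compound 2 to compound 3 (0.24 log units; that floor lies within the scatter), and replacing 2-chlorophenyl with it gives an at least 1.7-fold lower number from compound 1 to compound 3 (0.24 log units; that floor lies within the scatter). These steps are only floors, because the other two values are limits: the limit of > 50000 nM in this assay, at which 2 of the 3 values shown sit.

The compounds shown leave open whether the chlorine or the nitro group accounts for the readable value. They also leave open how an amine or a carboxylic acid on this phenyl ring would behave.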